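Swapping the aryl group on the exocyclic alkene

This account rests on a few compounds, and the source may have more. Where it says the series, first, only, none or still open, it means among the compounds named here.

The measured compounds and their values:

Compound 1 `O=C1N=C(N2CCC[C@H]2C(=O)Nc2ccc3ncnc(Nc4cccc(Cl)c4)c3c2)S/C1=C/c1cccnc1` — 10400 nM
Compound 2 `O=C1N=C(N2CCC[C@H]2C(=O)Nc2ccc3ncnc(Nc4cccc(Cl)c4)c3c2)S/C1=C/c1cccs1` — 6100 nM

Both compounds share a core and differ only in the aryl group on the exocyclic double bond. In a functional assay on A549 cells (Homo sapiens) for antiproliferative activity, read by MTT assay (a lower number here means a stronger inhibitor, a higher number a weaker inhibitor), compound 1 gives 10400 nM, while compound 2 gives 6100 nM. Among the measured compounds shown here, the single step between them, a 1.7-fold lower number from compound 1 to compound 2 (0.23 log units; within the scatter), so compound 2 carries the lowest of the two numbers, and its nearest neighbour, compound 1, sits within the scatter of it; no order between the two can be claimed.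

Compound 3 `COc1ccccc1/C=C1/SC(N2CCC[C@H]2C(=O)Nc2ccc3ncnc(Nc4cccc(Cl)c4)c3c2)=NC1=O` is not yet measured. Its difference from compound 2 is 2-methoxyphenyl in place of thiophen-2-yl on a double-bonded chain carbon bound to a double-bonded ring carbon. For the measured compounds named here, the only step that bears on this position is the one from compound 1 to compound 2, and it stayed within the scatter when one aromatic group replaced another at the same place. On that basis no step beyond the scatter is expected in this assay for compound 3, in either direction. The estimate for compound 3 in this assay is 6000 nM, with a range from 2500 nM to 15000 nM, which means an expected step of a 1.0-fold lower number from compound 2 to compound 3 (0.01 log units; within the scatter).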

Compound 3, half-maximal inhibitory concentration: > 50000 nM
Compound 3 gave a limit, no number; the forecaster's own chance of this, stated with the estimate: 5%; middle value at least 8.3-fold (0.92 log units) from the limit.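

Compound 3 gives only a limit in this assay, not a number: the limit of > 50000 nM in this assay, at which 1 of the 3 values shown sits.

Even so, the steps can be read, and there is an at least 8.1-fold higher number from compound 2 to compound 3 (0.91 log units; beyond the scatter), alongside an at least 4.8-fold higher number from compound 1 to compound 3 (0.68 log units; beyond the scatter). The earlier pair had stayed within the scatter when one aromatic group replaced another on the double-bonded chain carbon, whereas these two steps show that this place does not take every aromatic group alike: among the three compounds shown, 2-methoxyphenyl stands apart as the weaker inhibitor, with both thiophen-2-yl and pyridin-3-yl giving lower numbers.

What the compounds shown leave open is which part of the change carries the step, since 2-methoxyphenyl brings a six-membered aromatic ring of carbon only and a methoxy group in a single move, and thiophen-2-yl and pyridin-3-yl offer no such separation. A plain phenyl group at this place would speak to the ring alone, and a phenyl ring bearing a hydroxyl group or a fluorine atom instead of the methoxy group would speak to the substituent, but neither stands among the compounds shown here.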